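Piperidine carbamoyl triazoles: phenoxy extension from compound 2

The compounds below may be only part of what the source reports. "The series", "measured", "known", "first", "only" and "open" are said of these compounds alone.

Measured compounds:
- compound 1, `O=C(N1CCCC[C@@H]1Cc1ccccc1)n1ncc(C(O)(c2ccc(F)cc2)c2ccc(F)cc2)n1`, 0.794 nM
- compound 2, `CCC1CCCCN1C(=O)n1ncc(C(O)(c2ccccc2)c2ccccc2)n1`, 63.1 nM

In an assay on HEK-293T cells for inhibition of diacylglycerol lipase-alpha (Homo sapiens), read by colorimetric assay (on this read-out lower numbers stand for stronger inhibition and higher numbers for weaker inhibition), compound 2 gives 63.1 nM, the highest of the two numbers shown; compound 1 gives 0.794 nM, a gap beyond the scatter. Compound 3, `O=C(N1CCCCC1COc1ccc(F)cc1)n1ncc(C(O)(c2ccccc2)c2ccccc2)n1`, is not yet measured. It differs from compound 2 in one place: 4-fluorophenoxy in place of methyl on a saturated chain carbon bound to a saturated ring carbon. For the measured compounds named here, no single-point step toward this change exists among the measured pair, so the expectation rests on the two values alone. For compound 3 a lowered number is expected, a step of an 11-fold lower number from compound 2 to compound 3 (1.02 log units; beyond the scatter), estimated at 6 nM with a range of 1 nM to 40 nM.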

Compound 3, half-maximal inhibitory concentration: 6.31 nM
For compound 3 the middle estimate is 1.1-fold (0.02 log units) below the measured one; the measured number falls inside the stated range.
By their numbers in this assay, from the lowest: compound 1; then compound 3; then compound 2.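

Putting 4-fluorophenoxy in place of methyl on a saturated chain carbon bound to a saturated ring carbon gives a 10-fold lower number from compound 2 to compound 3 (1.00 log units; beyond the scatter) in this assay with the rest of the molecule unchanged. This place therefore takes an added aromatic ring and a hydrogen-bond acceptor, and the number falls rather than rises. Nothing measured here accounts for the step. Still open, from the compounds shown here alone, is how much of the step belongs to the fluorine and how much to the oxygen, and whether a plain phenoxy, a benzyl group or an amine at this place would give a similar step.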